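Taking the amino group away from compound 1

The compounds below may be only part of what the source reports. "The series", "measured", "known", "first", "only" and "open" are said of these compounds alone.

Within the data shown here, in a functional assay on KB cells (Homo sapiens) for antiproliferative activity, read by sulforhodamine B assay, with a stated time of 48 h (a lower number here means a stronger inhibitor of growth, a higher number a weaker inhibitor of growth), compound 1 (`COc1ccc(S(=O)(=O)Nc2ccccc2CCc2ccc(C(=O)Nc3ccccc3N)cc2)cc1`) gives 23 nM as the lowest of three numbers so far. Compound 2 (`Nc1ccccc1NC(=O)c1ccc(CCc2ccccc2NS(=O)(=O)c2ccccc2)cc1`) gives 456 nM and compound 3 (`COc1ccc(S(=O)(=O)Nc2ccccc2CCc2ccc(C(=O)Nc3ccccc3N)cc2)cc1OC`) gives 888 nM in the same test, so compound 1 stands clearly apart from both.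

Compound 4 (`COc1ccc(S(=O)(=O)Nc2ccccc2CCc2ccc(C(=O)Nc3ccccc3)cc2)cc1`) is compound 1 with hydrogen in place of amino on an aromatic carbon. Among the measured compounds shown here, all three measured compounds carry this amino group, so no measured step tests its loss directly. For the measured compounds named here, the only guide is how far single changes elsewhere moved the number. Removing the methoxy group of compound 1 gave a 20-fold higher number from compound 1 to compound 2 (1.30 log units; beyond the scatter) and adding a second methoxy gave a 39-fold higher number from compound 1 to compound 3 (1.59 log units; beyond the scatter) and both of these steps are large. Against that, a 1.9-fold higher number from compound 2 to compound 3 (0.29 log units; within the scatter) is no clear change.

A large move to a higher number is therefore expected, and the estimated step is a 130-fold higher number from compound 1 to compound 4 (2.12 log units; beyond the scatter) for this single change. The estimate for compound 4 is 3000 nM with an expected range from 400 nM to 30000 nM in this assay.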

Compound 4, concentration for 50% growth inhibition: 137 nM
Compound 4: the middle estimate sits 22-fold (1.34 log units) above what was measured, outside the stated range (below it).
By their numbers in this assay, from the lowest: compound 1; then compound 4; then compounds 2 and 3 (each within the scatter of the next).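

In this assay, among these compounds, this is the first direct test of the amino group, and the step to phenyl in place of 2-aminophenyl is a 6.0-fold higher number from compound 1 to compound 4 (0.77 log units; beyond the scatter), so the group counts but is not all-or-nothing at this place. Single changes at the methoxy end of compound 1 moved the number further, with a 20-fold higher number from compound 1 to compound 2 (1.30 log units; beyond the scatter) and a 39-fold higher number from compound 1 to compound 3 (1.59 log units; beyond the scatter), so among these compounds that end is the more sensitive of the two. Nothing available explains why the amino group makes this difference.

Going by these compounds, whether a hydroxyl group, a methyl group or a fluorine atom on the same carbon would bring the number back towards that of compound 1 stays open. So does whether losing the amino group would cost as much in compound 2 or compound 3.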